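The source may report more compounds than this note shows. Statements on the series, on what has been measured and on what is new or still open speak of the compounds shown alone.

Compound 1, `COc1ccccc1-c1nc2ncccn2c1NC1CCCCC1`, in a toxicity assay on A549 cells (Homo sapiens) for cytotoxicity, read by luminescence and CellTiter-Glo, with a stated time of 48 h (on this read-out higher numbers stand for lower toxicity in this test and lower numbers for higher toxicity in this test), reaches only the limit of the test, > 100000 nM. For the measured compounds named here, compound 2, `CCCCOc1ccc(-c2nc3ncccn3c2NC2CCCCC2)c(C)c1`, gives 32000 nM in this assay, the only actual number among the two values shown. The other value is a limit, as the limit of > 100000 nM in this assay, at which 1 of the 2 values shown sits, records for compound 1. Compound 3, `Cc1cc(Br)ccc1-c1nc2ncccn2c1NC1CCCCC1`, has not yet been measured in this assay. It differs from compound 2 by bromo in place of butoxy on an aromatic carbon. Going by the values given here, no measured pair that differs in a single place is available, so the size of such a step is not known from these data. Compound 3 is expected to move modestly toward lower toxicity in this assay, by an estimated step of a 1.9-fold higher number from compound 2 to compound 3 (0.27 log units; within the scatter), though a shift no larger than the usual scatter would not surprise. Compound 3 is estimated at 60000 nM, between 20000 nM and 200000 nM, with a fair chance that the test reports only a limit.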

Compound 3, half-maximal cytotoxic concentration: 45000 nM
For compound 3 the middle estimate is 1.3-fold (0.12 log units) above the measured one, and the stated range covers the measured number.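

In this assay, the first step read at this aromatic carbon, meta to a methyl group, is bromo in place of butoxy: a 1.4-fold higher number from compound 2 to compound 3 (0.15 log units; within the scatter). The two compounds cannot be told apart on this read-out, so here a single bromo and the longer butoxy chain, with its oxygen, give values within the scatter of each other. The change of the whole aryl group, 4-bromo-2-methylphenyl in place of 2-methoxyphenyl, gives an at least 2.2-fold lower number from compound 1 to compound 3 (0.34 log units; beyond the scatter), and the size of this step is only a bound, as it starts from a limit: the limit of > 100000 nM in this assay, at which 1 of the 3 values shown sits.

From the compounds shown here alone, whether an amine or a carboxylic acid on this carbon would also leave the number within the scatter stays open. So does which part of the aryl change, the bromo, the methyl or the loss of the methoxy, carries the step.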